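Ethylsulfonamide in Place of Methylsulfonamide on Two Anilide Cores

This account rests on a few compounds, and the source may have more. Where it says the series, first, only, none or still open, it means among the compounds named here.

Compound 1 `Cc1cc(NC(=O)c2ccc(Cl)c([N+](=O)[O-])c2)ccc1NS(C)(=O)=O` and compound 2 `CCS(=O)(=O)Nc1ccc(NC(=O)c2ccc(Cl)c([N+](=O)[O-])c2)cc1C` share one core. In an ADME assay on HEK293 cells (Homo sapiens) for cytotoxicity, read by MTT assay, with a stated time of 48 h (on this read-out lower numbers stand for stronger inhibition and higher numbers for weaker inhibition), compound 1 gives 73100 nM, and compound 2 gives 144000 nM. The change between them, (methyl in place of hydrogen on a saturated chain carbon bound to a sulfonyl sulfur), made a 2.0-fold higher number from compound 1 to compound 2 (0.29 log units; within the scatter). Compound 3 `COc1cc(NC(=O)c2cccc(C(F)(F)F)c2)ccc1NS(C)(=O)=O` rests on a different core; the difference between the two cores is not broken down here. In this assay compound 3 reaches only a limit, > 250000 nM. Compound 4 `CCS(=O)(=O)Nc1ccc(NC(=O)c2cccc(C(F)(F)F)c2)cc1OC` carries the same change on the core of compound 3, (methyl in place of hydrogen on a saturated chain carbon bound to a sulfonyl sulfur). The expected step is a step that the limit leaves unreadable from compound 3 to compound 4, in line with the measured one. Because compound 3 already sits at the limit of > 250000 nM in this assay, at which 1 of the 3 values shown sits, compound 4 is expected to give 300000 nM, most likely again reported only as a limit, with a range from 150000 nM to 600000 nM.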

Compound 4, half-maximal inhibitory concentration: > 250000 nM
Compound 4 gave a limit, no number; the forecaster's own chance of this, stated with the estimate: 85%; the middle value is on the limit's open side.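

Compound 3 and compound 4 are both reported only as limits, so no step can be read between them: the limit of > 250000 nM in this assay, at which 2 of the 4 values shown sit.

The compounds shown leave open whether methyl to ethyl at this place changes the read-out on the core of compound 3.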